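The compounds below may be only part of what the source reports. "The series", "measured", "known", "first", "only" and "open" are said of these compounds alone.

Measured so far:
compound 1, `Nc1ncnc2c1nc(NCc1ccc(-c3ccccc3)c(O)c1)n2[C@@H]1O[C@H](CO)[C@@H](O)[C@H]1O`: 1200 nM
compound 2, `CC(C)Oc1cc(CNc2nc3c(N)ncnc3n2[C@@H]2O[C@H](CO)[C@@H](O)[C@H]2O)ccc1-c1ccccc1`: 10400 nM

In an assay on COS-7 cells for inhibition of sodium/nucleoside cotransporter 2 (Homo sapiens), read by scintillation counting (a higher number here means a weaker inhibitor, a lower number a stronger inhibitor), compound 2 gives the highest of the two numbers; the nearest is compound 1, and the step of an 8.7-fold higher number from compound 1 to compound 2 (0.94 log units; beyond the scatter) lies beyond the scatter. Compound 3, `COC(=O)COc1cc(CNc2nc3c(N)ncnc3n2[C@@H]2O[C@H](CO)[C@@H](O)[C@H]2O)ccc1-c1ccccc1`, differs from compound 2 by (methoxycarbonyl)methyl in place of isopropyl on an oxygen on an aromatic ring. For the measured compounds named here, no measured step swaps one substituent on this oxygen for another; the only step at this position, an 8.7-fold higher number from compound 1 to compound 2 (0.94 log units; beyond the scatter), goes from hydrogen to isopropyl, and compound 3 keeps a substituent on the oxygen. In this assay the step of a 1.2-fold higher number from compound 2 to compound 3 (0.06 log units; within the scatter) is therefore expected to stay within the scatter. Compound 3 is estimated at 12000 nM, between 4000 nM and 40000 nM.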

Compound 3, half-maximal inhibitory concentration: 3300 nM
For compound 3 the middle estimate is 3.6-fold (0.56 log units) above the measured one; measured number outside the range, below it.
By their numbers in this assay, from the lowest: compound 1; then compound 3; then compound 2.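

In this assay the kind of substituent on this oxygen matters, not only its presence: a 3.2-fold lower number from compound 2 to compound 3 (0.50 log units; beyond the scatter) separates two groups that both cap the oxygen. The free hydroxyl of compound 1 still gives the lowest number of the three, with a 2.8-fold higher number from compound 1 to compound 3 (0.44 log units; beyond the scatter) remaining, so (methoxycarbonyl)methyl recovers only part of the loss seen with isopropyl. Nothing at hand explains the difference between these two groups. Open, as far as these compounds go, is whether the carbonyl or the chain carries the gain: a carboxylic acid, an amide or a longer chain on this oxygen would help separate the two.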